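Sulfur-linked aryl swap on a low-inhibition anilide

The source may report more compounds than this note shows. Statements on the series, on what has been measured and on what is new or still open speak of the compounds shown alone.

Of the compounds shown here, two have been measured in a functional assay on HCT-116 cells (Homo sapiens) for inhibition, read by CCK-8 assay, with a stated time of 72 h, tested at 8 uM; on this read-out higher numbers stand for more inhibition of growth at the one concentration tested and lower numbers for less inhibition of growth. Compound 1 `Cc1ccc(SCc2ccc(/C=C/C(=O)Nc3ccccc3N)cc2)cc1` shows 4.93% in this assay, the lowest of the two numbers. Compound 2 `Nc1ccccc1NC(=O)c1ccc(CSc2nccc(C(F)(F)F)n2)cc1`, of quite different build, gives 93.1% in this assay, a number that stands far higher than that of compound 1, though the two structures are not joined by a single step and nothing more can be read from that pair.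

The unmeasured compound 3 `Cc1cc(C)cc(SCc2ccc(/C=C/C(=O)Nc3ccccc3N)cc2)c1` is compound 1 with one change, (3,5-dimethylphenyl in place of 4-methylphenyl on a sulfur), the rest of the molecule being kept. Within the data shown here, no measured pair shows this kind of change, so there is no step in hand on which to lean. Since the shared core and the linking sulfur stay as they are, the author expects the step of a number 3.1 percentage points higher from compound 1 to compound 3 (within the scatter) to be small and not beyond the usual scatter, in either direction. On that basis compound 3 is estimated to give 8% in this assay, with a range from 0% to 25%, the measurement that will decide it being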

Compound 3, percent growth inhibition at one concentration: 4.2%
Compound 3: middle estimate off by 3.8 percentage points, on the high side, and the stated range covers the measured number.
By their numbers in this assay, from the lowest: compounds 3 and 1 (each within the scatter of the next); then compound 2.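

Among these compounds, with the step of a number 0.7 percentage points lower from compound 1 to compound 3 (within the scatter) in this assay, this is the first reading of a change at the aryl group on the sulfur, and it places 3,5-dimethylphenyl and 4-methylphenyl within the scatter of each other. For this pair, then, the change from one methyl-bearing phenyl group to the other gives no growth-inhibition difference that this read-out can resolve at its single tested concentration, with the rest of the molecule kept. The data shown offer no measured basis for explaining this result.

On these data alone, what remains open is whether this position responds at all to groups of another kind, such as an amine or a carboxylic acid on the phenyl ring, or a longer chain on the sulfur in place of the ring. Among the compounds shown here, also unresolved is whether the same change would behave alike on a different core, since this single pair gives only one reading of it, and no step joins either compound to any other scaffold.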